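The compounds below may be only part of what the source reports. "The series", "measured", "known", "first", "only" and "open" are said of these compounds alone.

Measured so far in a functional assay on HT-1080 cells (Homo sapiens) for cytotoxicity, read by MTT assay, with a stated time of 72 h; on this read-out lower numbers stand for stronger inhibition and higher numbers for weaker inhibition:
- compound 1 `COc1cccc(/C=C2\CCC/C(=C\c3ccc(Cl)cc3)C2=O)c1OC`: 11100 nM
- compound 2 `COc1cccc(/C=C2\CCC/C(=C\c3cccc(OC)c3OC)C2=O)c1`: 9900 nM

Compound 2 holds the lower of the two numbers only nominally, since its value and that of compound 1 lie within the scatter of each other. Neither compound stands apart on these data.

The next compound is compound 3 `COc1ccc(/C=C2\CCC/C(=C\c3cccc(OC)c3OC)C2=O)cc1`. The change is 4-methoxyphenyl in place of 3-methoxyphenyl on a double-bonded chain carbon bound to a double-bonded ring carbon.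

Going by the values given here, one measured step bears on this change, at the same place: a 1.1-fold lower number from compound 1 to compound 2 (0.05 log units; within the scatter), with 3-methoxyphenyl in place of 4-chlorophenyl. Among the compounds with values here, no measurement yet compares the two methoxyphenyl groups directly, so this single step offers limited guidance.

Going by compound 2 at 9900 nM and that one step, no change beyond the scatter is expected in this assay, and neither direction is favoured. The expected outcome is a 1.0-fold higher number from compound 2 to compound 3 (0.00 log units; within the scatter). Compound 3 is estimated at 10000 nM, with an expected range of 4000 nM to 25000 nM.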

Compound 3, half-maximal inhibitory concentration: 16300 nM
Compound 3: the middle estimate sits 1.6-fold (0.21 log units) below what was measured; measured number inside the range.
By their numbers in this assay, from the lowest: compounds 2, 1 and 3 (each within the scatter of the next).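

In this assay, going by these compounds alone, 4-methoxyphenyl in place of 3-methoxyphenyl on a double-bonded chain carbon bound to a double-bonded ring carbon gives a 1.6-fold higher number from compound 2 to compound 3 (0.22 log units; within the scatter) as the first direct comparison of these two groups, and the two compounds cannot be separated on this read-out. Methoxy in place of chloro on an aromatic carbon gives a 1.5-fold higher number from compound 1 to compound 3 (0.17 log units; within the scatter) and also stays within the scatter, so 4-chlorophenyl, 3-methoxyphenyl and 4-methoxyphenyl at this place are not distinguished by these numbers, and the series so far shows no dependence on which of the three is present. No accompanying data bear on why these compounds sit so close together.

All the changes shown are swaps among substituted phenyl groups at this one place, so it remains open whether a group of a different kind there, such as an aminomethylphenyl, a carboxylic acid on the phenyl ring or a pyridine ring, would move the number beyond the scatter. From the compounds shown here alone, the contribution of the rest of the shared core also remains open, as it is unchanged across the compounds compared here.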